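A few compounds are considered here, and "the series" means these few. Any claim that something is new, unique, unknown or untested is made for them only; others in the source may bear on it.

Among the compounds with values here, in a physicochemical assay for solubility, read by chemiluminescence, measured as kinetic solubility (a higher number here means a more soluble compound, a lower number a less soluble compound), compound 3 `O=C(C1CCCCC1)N1CCC2(CCN(c3nccc(NCc4ccc(Cl)cc4Cl)n3)CC2)C1` gives 3 ug/mL, the lowest of the three numbers so far, against compound 1 `O=C([C@@H]1CCCN1)N1CCC2(CCN(c3nccc(NCc4ccc(Cl)cc4Cl)n3)CC2)C1` at 165 ug/mL and compound 2 `O=C(C1CCCNC1)N1CCC2(CCN(c3nccc(NCc4ccc(Cl)cc4Cl)n3)CC2)C1` at 186 ug/mL. Compound 4 `O=C(c1ccccn1)N1CCC2(CCN(c3nccc(NCc4ccc(Cl)cc4Cl)n3)CC2)C1` changes only the group on a carbonyl carbon: pyridin-2-yl in place of cyclohexyl on a carbonyl carbon. Within the data shown here, two measured steps touch this place, both large and both arriving at cyclohexyl: a 55-fold lower number from compound 1 to compound 3 (1.74 log units; beyond the scatter) and a 62-fold lower number from compound 2 to compound 3 (1.79 log units; beyond the scatter). Read backwards, they suggest that replacing cyclohexyl may raise the number. However, no measured compound carries an aromatic ring here, so they are only a loose guide. In this assay, the expected step is a moderate rise, a 6.7-fold higher number from compound 3 to compound 4 (0.82 log units; beyond the scatter). For compound 4, the estimated value is 20 ug/mL, with an expected range of 6 ug/mL to 80 ug/mL.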

Compound 4, solubility: 17 ug/mL
Beside the measured number, compound 4's estimate is 1.2-fold (0.07 log units) above it; low and high end bracket the measured number.
By their numbers in this assay, from the lowest: compound 3; then compound 4; then compounds 1 and 2 (each within the scatter of the next).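

Among the compounds shown, only compound 4 carries an aromatic ring on the carbonyl carbon, and in this assay pyridin-2-yl recovers only part of what cyclohexyl loses: a 5.7-fold higher number from compound 3 to compound 4 (0.75 log units; beyond the scatter), yet an 11-fold lower number from compound 2 to compound 4 (1.04 log units; beyond the scatter) and a 9.7-fold lower number from compound 1 to compound 4 (0.99 log units; beyond the scatter). This place therefore gives an intermediate level, not just a high and a low one. No measurement here explains that level. Still open, on these data alone, is whether phenyl, with carbon only in its ring, would sit nearer compound 3 or compound 4. An open-chain amine such as aminomethyl also remains untested among these compounds.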